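Trifluorophenyl in Place of a Trifluoromethyl-Bearing Ring

The source may hold more compounds than are shown below. What is called first, only, known or untested is meant among the compounds shown, and "the series" means these compounds.

Among the measured compounds shown here, compound 2 `CCc1nc(Cl)c2n1CCN([C@@H](C(=O)NC)c1ccccc1)[C@H]2CCc1ccc(C(F)(F)F)cc1F` gives 12 nM in a functional assay on CHO cells for antagonist activity at Orexin receptor type 2 (Homo sapiens), read by FLIPR and calcium flux (a lower number here means a stronger inhibitor, a higher number a weaker inhibitor), the highest of the two numbers so far; compound 1 `CCc1nc(Cl)c2n1CCN([C@@H](C(=O)NC)c1ccccc1)[C@H]2COc1cccc(C(F)(F)F)c1` gives 4 nM in this assay. Compound 3 `CCc1nc(Cl)c2n1CCN([C@@H](C(=O)NC)c1ccccc1)[C@H]2CCc1ccc(F)c(F)c1F` differs from compound 2 by 2,3,4-trifluorophenyl in place of 2-fluoro-4-(trifluoromethyl)phenyl on a saturated chain carbon, two bonds along the chain from a saturated ring carbon. For the measured compounds named here, the one measured step, a 3.0-fold higher number from compound 1 to compound 2 (0.48 log units; beyond the scatter), changed a different part of the molecule, so it does not speak directly to this change. With nothing comparable measured, the expected step is a 1.3-fold higher number from compound 2 to compound 3 (0.10 log units; within the scatter) in this assay, not beyond the scatter. The estimate for compound 3 is therefore 15 nM, within 5 nM to 50 nM.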

Compound 3, half-maximal inhibitory concentration: 5 nM
Compound 3: the middle estimate sits 3.0-fold (0.48 log units) above what was measured; the measured number falls inside the stated range.
By their numbers in this assay, from the lowest: compounds 1 and 3 (each within the scatter of the next); then compound 2.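

In this assay, the 2,3,4-trifluorophenyl ring in place of 2-fluoro-4-(trifluoromethyl)phenyl gives a 2.4-fold lower number from compound 2 to compound 3 (0.38 log units; beyond the scatter), so in this pair the trifluoromethyl group is not required for inhibition. The 2,3,4-trifluorobenzyl group also compares with the 3-(trifluoromethyl)phenoxy group, giving a 1.3-fold higher number from compound 1 to compound 3 (0.10 log units; within the scatter). No available evidence bears on this result. Still open, on these data alone, is how much each of the three fluorines contributes on its own, and how this position would respond to a longer chain or to a ring carrying an amine or a carboxylic acid.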